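A few compounds are considered here, and "the series" means these few. Any claim that something is new, unique, unknown or untested is made for them only; others in the source may bear on it.

Measured compounds:
Compound 1 `O=C(Cn1nnc(-c2ccccc2)n1)Nc1cc(C2(C(F)(F)F)CC2)nn1C1CCCCC1` — in an assay on HEK293 cells for activation of Kir3.1/Kir3.2 (Homo sapiens), read by thallium flux (a lower number here means that less compound is needed, a higher number that more compound is needed for the effect), compound 1 is reported as "not active" (no number reported).
Compound 2 `Cc1cc(NC(=O)Cn2nnc(-c3ccc(Cl)c(Cl)c3)n2)n(C2CCCCC2)n1` — in this assay compound 2 gives 1220 nM.

For the measured compounds named here, compound 2 holds the only numerical value in this assay; compound 1 stands beside it without a number. Compound 3 `Cc1cccc(-c2nnn(CC(=O)Nc3cc(C)nn3C3CCCCC3)n2)c1` has not been measured. It differs from compound 2 in a single place: 3-methylphenyl in place of 3,4-dichlorophenyl on an aromatic carbon. Going by the values given here, no step between two measured compounds is available, so the size of this change cannot be read off from the data and can only be expected. The removal of both chlorine atoms, with compound 1 reported as "not active" (no number reported), points toward a weaker result rather than a gain. Compound 3 is therefore expected to need more compound than compound 2, an estimated step of a 2.9-fold higher number from compound 2 to compound 3 (0.46 log units; beyond the scatter) that lies beyond the scatter. The estimate for compound 3 in this assay is 3500 nM, with a range from 1200 nM to 10000 nM.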

Compound 3, half-maximal effective concentration: 129 nM
Compound 3: the middle estimate sits 27-fold (1.43 log units) above what was measured; the whole stated range lies above it.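

In this assay, the aromatic carbon of the five-membered aromatic ring with 4 nitrogen tolerates the loss of both chlorine atoms: replacing 3,4-dichlorophenyl with 3-methylphenyl gives a 9.5-fold lower number from compound 2 to compound 3 (0.98 log units; beyond the scatter), so the chlorine atoms are not required for a low number in this series. For the compounds shown here, compound 1 differs from compound 2 in more than one place and carries no number, so no step involving it can be read. Nothing available accounts for the size of this step.

Compound 3 removes the chlorine atoms and adds the methyl group in one change, so a plain phenyl or a 3-chlorophenyl group on the same core would be needed to separate the two. Going by these compounds, it also remains open how the 3-methylphenyl group would behave with the trifluoromethyl-bearing cyclopropyl group of compound 1 in place of the core's methyl group.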